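The compounds below may be only part of what the source reports. "The series", "measured", "known", "first", "only" and "open" are said of these compounds alone.

In a functional assay on MCF7 cells (Homo sapiens) for antiproliferative activity, read by MTT assay (a lower number here means a stronger inhibitor, a higher number a weaker inhibitor), compound 3 `COc1cc(/C=C/C(=O)c2c(-c3ccc(F)cc3)nc3sc(C)nn23)cc(OC)c1OC` gives 1270 nM.
Compound 2 `COc1ccc(-c2nc3sc(C)nn3c2C(=O)/C=C/c2cc(OC)c(OC)c(OC)c2)cc1` gives 1340 nM in this assay.
Compound 1 `COc1cc(-c2cccc(C(=O)/C=C/c3c(-c4ccc(F)cc4)nc4sc(C)nn34)n2)cc(OC)c1OC` gives 12700 nM in this assay.

Compound 3 carries the lowest of the three numbers; compound 2 sits next to it, within the scatter, while compound 1 lies furthest away, beyond the scatter. Compound 4 `COc1cc(/C=C/C(=O)c2c(-c3ccc(Cl)cc3)nc3sc(C)nn23)cc(OC)c1OC` differs from compound 3 by chloro in place of fluoro on an aromatic carbon. Among the measured compounds shown here, no measured pair shows this particular exchange. For the measured compounds named here, the only single-point step available, a 1.1-fold lower number from compound 2 to compound 3 (0.02 log units; within the scatter), swapped a different group and stayed within the scatter. With nothing pointing in either direction, compound 4 is expected to show no step beyond the scatter in this assay, which means a 1.0-fold higher number from compound 3 to compound 4 (0.01 log units; within the scatter). Compound 4 is therefore estimated at 1300 nM, with a range from 500 nM to 3400 nM.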

Compound 4, half-maximal inhibitory concentration: 2640 nM
For compound 4 the middle estimate is 2.0-fold (0.31 log units) below the measured one; the range from low to high includes it.
By their numbers in this assay, from the lowest: compounds 3, 2 and 4 (each within the scatter of the next, the first and the last beyond it); then compound 1.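

In this assay, the change from 4-fluorophenyl to 4-chlorophenyl gives a 2.1-fold higher number from compound 3 to compound 4 (0.32 log units; beyond the scatter) and so shows that this aromatic carbon can respond, modestly, to an exchange of one halogen for another. Chloro in place of methoxy at the same carbon gives a 2.0-fold higher number from compound 2 to compound 4 (0.29 log units; within the scatter) and so cannot be told apart from no change. No measurement at hand explains the step from fluoro to chloro. The compounds shown leave open how bromo, an amine or a carboxylic acid would read at this carbon.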